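This account rests on a few compounds, and the source may have more. Where it says the series, first, only, none or still open, it means among the compounds named here.

Of the compounds shown here, two that share one core have so far been measured in a functional assay on PC-12 cells (Rattus norvegicus) for cytotoxicity, read by MTT assay, with stated times of 3 h and 2 h, tested at 20 uM; on this read-out lower numbers stand for a weaker effect and higher numbers for a stronger effect at the one concentration tested. Compound 1 `Cc1cc(=O)oc2cc(OCCCn3cc(CNC(=O)CCCCC4CCSS4)nn3)ccc12` gives 74.3% in this assay. Compound 2 `CC(=O)c1cc2ccc(OCCCn3cc(CNC(=O)CCCCC4CCSS4)nn3)cc2oc1=O` gives 39.8% in this assay, the lower of the two numbers, and the gap to compound 1 lies beyond the usual scatter. Compound 3 `O=C(CCCCC1CCSS1)NCc1cn(CCCOc2ccc3cc(C(=O)O)c(=O)oc3c2)nn1` has not yet been measured in this assay. It differs from compound 2 in one place: hydroxy in place of methyl on a carbonyl carbon; stated one bond further out, an acetyl gives way to a carboxy. For the measured compounds named here, no pair of measured compounds shows a change of this kind, so its effect in this assay is not known from the data. Compound 3 is therefore expected to stay close to compound 2, with an expected step of a number 7.8 percentage points lower from compound 2 to compound 3 (within the scatter) that may fall within the scatter or a little below it. Compound 3 is estimated at 32%, within a range from 12% to 55%, because compound 2 gives 39.8% in this assay.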

Compound 3, a percentage reported as activity, at one concentration (the size of the read-out at that concentration, not a potency): 66.8%
Beside the measured number, compound 3's estimate is 34.8 percentage points below it; measured number outside the range, above it.
By their numbers in this assay, from the lowest: compound 2; then compounds 3 and 1 (each within the scatter of the next).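

In this assay, for the compounds shown here, the group on this carbonyl carbon proves able to shift the read-out: hydroxy in place of methyl gives a number 27 percentage points higher from compound 2 to compound 3 (beyond the scatter) and is the first single change that can be read. The swap of acetyl to carboxy exchanges one heavy atom for one and adds one hydrogen-bond donor, and that alone is enough to carry the number beyond the scatter at the one concentration tested. No measurement at hand accounts for the step.

Whether the hydroxy is special or other groups on this carbonyl carbon would do the same stays open, as an amine, giving a primary amide, or a methoxy, giving a methyl ester, is not among the compounds shown. A single step also leaves open whether the same change would move the number as far on a different side chain.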